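The source may report more compounds than this note shows. Statements on the series, on what has been measured and on what is new or still open speak of the compounds shown alone.

Of the compounds shown here, three built on one shared core have been measured in a functional assay on the whole organism (strain albino) for inhibition, with Rattus norvegicus as the target, read by paw edema, with stated times of 30 min and 2 h, at a dose of 100 mg/kg by the oral route; on this read-out higher numbers stand for more inhibition at the one dose given (going by the name of the read-out) and lower numbers for less inhibition. Compound 1 `O=C(CBr)Nc1ccc(C(=O)/C=C/c2ccc(Cl)cc2)cc1` gives 52%, compound 2 `O=C(CO[N+](=O)[O-])Nc1ccc(C(=O)/C=C/c2ccc(Cl)cc2)cc1` gives 57%, and compound 3 `CC(=O)c1ccc(OCC(=O)Nc2ccc(C(=O)/C=C/c3ccc(Cl)cc3)cc2)cc1` gives 52%. Compound 3 stands level with compound 1 at the digits given, and the step of a number 5 percentage points lower from compound 2 to compound 3 (within the scatter) is within the scatter, so the three numbers cannot be told apart. The step of a number 5 percentage points higher from compound 1 to compound 2 (within the scatter) and the step of no change at the digits printed from compound 1 to compound 3 (within the scatter) likewise lie within the scatter.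

Compound 4 `C/C(=N/O)c1ccc(OCC(=O)Nc2ccc(C(=O)/C=C/c3ccc(Cl)cc3)cc2)cc1` differs from compound 3 at one spot on the outer ring: a group of 4 heavy atoms (2 carbon, 1 nitrogen, 1 oxygen; no ring) in place of a group of 3 heavy atoms (2 carbon, 1 oxygen; no ring), on an aromatic carbon. Going by the values given here, no measured step touches this group directly. The nearest comparisons are the step of no change at the digits printed from compound 1 to compound 3 (within the scatter), which brings in the whole 4-acetylphenoxy group, and the step of a number 5 percentage points lower from compound 2 to compound 3 (within the scatter); both remained within the scatter. On that basis the expected step is a number 1 percentage points higher from compound 3 to compound 4 (within the scatter), none beyond the scatter. Compound 4 is therefore estimated at 53%, with a range from 41% to 65%.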

Compound 4, a percentage reported as inhibition, in the whole organism at one dose (the size of the read-out at that dose, not a potency): 54%
For compound 4 the middle estimate is 1 percentage points below the measured one; the measured number falls inside the stated range.
By their numbers in this assay, from the lowest: compounds 1, 3, 4 and 2 (each within the scatter of the next).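

Going by these compounds alone, on an aromatic carbon para to a large group, putting the group of 4 heavy atoms in place of acetyl brings 1 hydrogen-bond donor where acetyl has 0, and in this assay this gives a number 2 percentage points higher from compound 3 to compound 4 (within the scatter), so this is the first sign that a change at this far position can be made without a difference that can be told from scatter. The group of 10 heavy atoms in place of nitro on the oxygen gives a number 3 percentage points lower from compound 2 to compound 4 (within the scatter), so the compound with the extended side arm also cannot be told apart from the one with the small nitrooxy end. No measurement here bears on why these numbers sit so close together.

From the compounds shown here alone, whether a carboxylic acid or an amine at this same place would move the number beyond the scatter remains open. So does whether a longer chain between the amide carbonyl and the outer ring would do so.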